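A few compounds are considered here, and "the series" means these few. Any claim that something is new, unique, unknown or untested is made for them only; others in the source may bear on it.

Measured compounds:

compound 1 `COc1cc(OC)c(C(=O)/C=C/c2ccccc2SC)c(OC)c1` gives 36% in a functional assay on Caco-2 cells (Homo sapiens), read by fluorescence and BrdU incorporation, with a stated time of 48 h, tested at 10 uM; a higher number here means a weaker effect of the compound at the concentration tested, a lower number a stronger effect
compound 2 `COc1cccc(/C=C/C(=O)c2c(OC)cc(OC)cc2OC)c1` gives 31% in this assay

Of the two numbers shown, compound 2 has the lowest, with compound 1 as its only neighbour; the step of a number 5 percentage points lower from compound 1 to compound 2 (within the scatter) means the two values cannot be told apart, so neither compound is called the stronger one. Compound 3 `COc1cc(OC)c(C(=O)/C=C/c2ccc(Cl)cc2)c(OC)c1` has not yet been measured in this assay. It differs from compound 2 in one place: 4-chlorophenyl in place of 3-methoxyphenyl on a double-bonded chain carbon bound to a double-bonded chain carbon. Going by the values given here, the only measured step, a number 5 percentage points lower from compound 1 to compound 2 (within the scatter), exchanges one group on that same chain carbon for another and stayed within the scatter; no measured pair exchanges 3-methoxyphenyl for 4-chlorophenyl, so nothing here speaks directly to this change. Since both groups so far tried at this position gave values within the scatter of each other, the step of a number 2 percentage points higher from compound 2 to compound 3 (within the scatter) is expected to stay within the scatter as well, with no clear direction. Compound 3 is therefore estimated at 33%, with a likely range from 15% to 55%.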

Compound 3, a percentage reported as activity, at one concentration (the size of the read-out at that concentration, not a potency): 39%
Compound 3: middle estimate off by 6 percentage points, on the low side, within the range that was stated.
By their numbers in this assay, from the lowest: compounds 2, 1 and 3 (each within the scatter of the next).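

In this assay the exchange for 4-chlorophenyl on a double-bonded chain carbon bound to a double-bonded chain carbon gives a number 8 percentage points higher from compound 2 to compound 3 (within the scatter) and a number 3 percentage points higher from compound 1 to compound 3 (within the scatter), so the three groups tried at this place now cannot be told apart. The earlier pair held only groups with a sulfur or oxygen substituent, whereas this exchange brings in chlorine and takes the count of hydrogen-bond acceptors in the group from 1 to 0, and the read-out at the concentration tested still stays within the scatter for both steps. Nothing available explains this insensitivity, and no independent measurement bears on these exchanges.

From the compounds shown here alone, all three compounds carry a substituted phenyl ring at this place, so it stays open whether a quite different group, such as a carboxylic acid or an amine on that ring, or a longer alkyl chain in place of the ring, would move the number beyond the scatter. The compounds shown also share one core, and they say nothing about what a change there would do.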